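The compounds below may be only part of what the source reports. "The series", "measured", "known", "first", "only" and "open" are said of these compounds alone.

Measured in a functional assay on RAW264.7 cells (Mus musculus) for inhibition, with stated times of 1 h and 24 h; a higher number here means a weaker inhibitor, a lower number a stronger inhibitor:
- compound 1 `COc1ccccc1C(=O)Nc1cccc(-c2cc(=O)c3c(OC)c(OC)c(OC)cc3o2)c1`: "not determined" (no result reported)
- compound 2 `COc1ccccc1NC(=O)c1cccc(-c2cc(=O)c3c(OC)c(OC)c(OC)cc3o2)c1`: 1990 nM

Among the compounds with values here, compound 2 at 1990 nM holds the only number, so it has no rank against any other compound. Compound 3 `COc1cc(NC(=O)c2cccc(-c3cc(=O)c4c(OC)c(OC)c(OC)cc4o3)c2)cc(OC)c1OC` carries 3,4,5-trimethoxyphenyl in place of 2-methoxyphenyl on an amide-type nitrogen. Within the data shown here, no measured step exists to size this change, and the expectation rests only on compound 2 at 1990 nM. The expected step is a 1.1-fold lower number from compound 2 to compound 3 (0.04 log units; within the scatter), none beyond the scatter in this assay. Compound 3 is estimated at 1800 nM, with an expected range of 500 nM to 6000 nM.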

Compound 3, half-maximal inhibitory concentration: 3400 nM
Compound 3: the middle estimate sits 1.9-fold (0.28 log units) below what was measured, and the stated range covers the measured number.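

In this assay, placing 3,4,5-trimethoxyphenyl in place of 2-methoxyphenyl on the amide-type nitrogen gives a 1.7-fold higher number from compound 2 to compound 3 (0.23 log units; within the scatter). This position therefore accepts the larger aryl group, with its extra methoxy groups, with no shift beyond the scatter. No available evidence bears on the origin of this result.

Still open, as far as these compounds go, is whether this position stays as flat when the aryl group gives way to something other than a methoxy-substituted phenyl, such as a morpholine or a carboxylic acid.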